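This account rests on a few compounds, and the source may have more. Where it says the series, first, only, none or still open, it means among the compounds named here.

In an assay on HEK293 cells for displacement of a labelled ligand from NPC1-like intracellular cholesterol transporter 1 (Homo sapiens) (on this read-out higher numbers stand for weaker inhibition and lower numbers for stronger inhibition), compound 1 `CC(C)(C)OC(=O)NC1CCN(C(=O)CN2CN(c3ccccc3)C3(CCN(C(=O)c4ccc(C(C)(C)C)cc4)CC3)C2=O)CC1` gives 8300 nM, the largest of the three numbers shown, though both other compounds lie within the usual scatter of it: compound 2 `CC(C)(C)c1ccc(C(=O)N2CCC3(CC2)C(=O)N(CC(=O)N2CCCCC2CCO)CN3c2ccccc2)cc1` gives 6100 nM and compound 3 `CC(C)(C)OC(=O)NC1CCN(C(=O)CN2CN(c3ccccc3)C3(CCN(C(=O)c4ccc(C5CCCCC5)cc4)CC3)C2=O)CC1` gives 4800 nM. Compound 4 `CCc1nn(CC)c(C2CCN(C(=O)CN3CN(c4ccccc4)C4(CCN(C(=O)c5ccc(C(C)(C)C)cc5)CC4)C3=O)CC2)c1C` carries 1,3-diethyl-4-methyl-1H-pyrazol-5-yl in place of (tert-butoxycarbonyl)amino on a saturated ring carbon. Within the data shown here, the only step between measured compounds that differ in one place, a 1.7-fold lower number from compound 1 to compound 3 (0.24 log units; within the scatter), concerns a different part of the molecule and stays within the scatter, so it offers little guidance here. Compound 2, altered in the same region as compound 4, simply shows a number of the same order as compound 1. Compound 4 is therefore expected to move by about a 1.4-fold lower number from compound 1 to compound 4 (0.14 log units; within the scatter), no more than the scatter. The estimated value for compound 4 is 6000 nM, with a range from 1500 nM to 25000 nM.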

Compound 4, half-maximal inhibitory concentration: 2500 nM
Beside the measured number, compound 4's estimate is 2.4-fold (0.38 log units) above it, within the range that was stated.
By their numbers in this assay, from the lowest: compounds 4, 3, 2 and 1 (each within the scatter of the next, the first and the last beyond it).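

Putting 1,3-diethyl-4-methyl-1H-pyrazol-5-yl in place of (tert-butoxycarbonyl)amino on the saturated ring carbon gives a 3.3-fold lower number from compound 1 to compound 4 (0.52 log units; beyond the scatter) in this assay, the first step among these compounds to pass the scatter. This position therefore accepts an aromatic ring with no hydrogen-bond donor, and the donor that leaves is not required for this level of inhibition. No measurement here explains the lower number. Going by these compounds, it remains open whether the ring or its ethyl and methyl groups account for the step. A bare pyrazolyl ring or a simple amine on the same carbon would help separate these.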